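Aryl swaps on the shared core: toward compound 4

A few compounds are considered here, and "the series" means these few. Any claim that something is new, unique, unknown or untested is made for them only; others in the source may bear on it.

Values in a functional assay on KYSE-410 cells (Homo sapiens) for antiproliferative activity, read by MTT assay, with a stated time of 72 h; a higher number here means a weaker inhibitor, a lower number a stronger inhibitor:
- compound 1 `O=C(Nc1cccc(F)c1)c1cc(=O)[nH]c2cc(Br)ccc12`: 7300 nM
- compound 2 `O=C(Nc1cccc(F)c1)c1cc(=O)[nH]c2cc(-c3ccc(F)cc3)ccc12`: 10300 nM
- compound 3 `CC(=O)c1ccc(-c2ccc3c(C(=O)Nc4cccc(F)c4)cc(=O)[nH]c3c2)cc1`: > 20000 nM

Compound 3 gives > 20000 nM, which is a limit of the assay and not a number.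

Compound 4 `O=C(Nc1cccc(F)c1)c1cc(=O)[nH]c2cc(-c3ccsc3)ccc12` carries thiophen-3-yl in place of the 4-acetylphenyl of compound 3, on an aromatic carbon of the shared core: thiophen-3-yl in place of 4-acetylphenyl on an aromatic carbon.

Among the measured compounds shown here, three measured steps bear on this change. With 4-fluorophenyl in place of bromo, the step is a 1.4-fold higher number from compound 1 to compound 2 (0.15 log units; within the scatter). With 4-acetylphenyl in place of bromo, the step is an at least 2.7-fold higher number from compound 1 to compound 3 (0.43 log units; beyond the scatter). With acetyl in place of fluoro, the step is an at least 1.9-fold higher number from compound 2 to compound 3 (0.28 log units; that floor lies within the scatter).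

Compound 4 has no acetyl group, so the nearest guide is compound 2 at 10300 nM, and a move to a lower number is expected in this assay. Its size remains uncertain, as the starting point is only a limit. The expected step is an at least 2.0-fold lower number from compound 3 to compound 4 (0.30 log units; that floor lies within the scatter). For compound 4 the estimated value is 10000 nM, with an expected range of 4500 nM to 20000 nM.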

Compound 4, half-maximal inhibitory concentration: 4300 nM
Compound 4: the middle estimate sits 2.3-fold (0.37 log units) above what was measured; measured number below the stated range.
By their numbers in this assay, from the lowest: compounds 4, 1 and 2 (each within the scatter of the next, the first and the last beyond it). At a limit, above all of these: compound 3.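

In this assay, no earlier aryl swap at this position gave a step to a lower number, whereas thiophen-3-yl in place of 4-fluorophenyl gives a 2.4-fold lower number from compound 2 to compound 4 (0.38 log units; beyond the scatter), so the choice of aryl group can move the number down. Against bromo there is no such gain, with a 1.7-fold lower number from compound 1 to compound 4 (0.23 log units; within the scatter), and the two groups cannot be ordered here. Against 4-acetylphenyl the step is an at least 4.6-fold lower number from compound 3 to compound 4 (0.66 log units; beyond the scatter), and it is only a floor, since compound 3 stands at a limit of the assay and not at a number: the limit of > 20000 nM in this assay, at which 1 of the 4 values shown sits.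

Ring size and the sulfur atom change together in compound 4, and the compounds shown do not separate them. Also open, from the compounds shown here alone, is whether furan-3-yl or pyridin-3-yl would follow thiophen-3-yl, and whether an amine on the aryl ring would behave like the acetyl group of compound 3.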